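Allyl for Phenyl on the Triazole Nitrogen

A few compounds are considered here, and "the series" means these few. Any claim that something is new, unique, unknown or untested is made for them only; others in the source may bear on it.

Compound 2 `COc1ccc(-c2nnc(SCC(=O)Nc3ccc(/C(C)=N/O)cc3)n2-c2ccccc2)cc1OC` is examined in a functional assay on the whole organism (strain albino) for inhibition, with Rattus norvegicus as the target, read by paw edema, with stated times of 30 min and 2 h, at a dose of 0.28 mmol/kg by the oral route (a higher number here means more inhibition at the dose given (going by the name of the read-out), a lower number less inhibition), where compound 2 gives 63%. Among the measured compounds shown here, the only other compound measured, compound 1 `C=CCn1c(SCC(=O)Nc2ccc(/C(C)=N/O)cc2)nnc1-c1ccccc1`, gives 63% in this assay, so compound 2 and compound 1 lie within the scatter of each other. Compound 3 `C=CCn1c(SCC(=O)Nc2ccc(/C(C)=N/O)cc2)nnc1-c1ccc(OC)c(OC)c1` has not been measured. It differs from compound 2 by allyl in place of phenyl on an aromatic nitrogen. For the measured compounds named here, with no measured step available for this change, the expected step of no change at the digits printed from compound 2 to compound 3 (within the scatter) is none beyond the scatter, because compound 1 gives 63% and compound 2 gives 63% in this assay. Compound 3 is therefore estimated at 63%, with a range from 50% to 75%.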

Compound 3, a percentage reported as inhibition, in the whole organism at one dose (the size of the read-out at that dose, not a potency): 56%
For compound 3 the middle estimate is 7 percentage points above the measured one; low and high end bracket the measured number.
By their numbers in this assay, from the lowest: compounds 3, 1 and 2 (each within the scatter of the next).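

In this assay, allyl in place of phenyl on the aromatic nitrogen gives a number 7 percentage points lower from compound 2 to compound 3 (within the scatter) with the 3,4-dimethoxyphenyl group present, so this position carries either group within the scatter. With allyl on that nitrogen, 3,4-dimethoxyphenyl in place of phenyl on the aromatic carbon gives a number 7 percentage points lower from compound 1 to compound 3 (within the scatter) and neither single change goes beyond the scatter. No measurement here offers an explanation for these values. The compounds shown leave open whether a methyl, a benzyl or a longer alkyl chain on this nitrogen would stay within the same scatter. They also leave open how an aminoalkyl chain or a carboxylic acid there would read out.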